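The compounds below may be only part of what the source reports. "The series", "measured", "known", "first", "only" and "open" are said of these compounds alone.

Compounds measured so far:
compound 1 `O=C(CCC1=CCCN(Cc2ccc(F)cc2)C1=O)NO` - "not determined" (no result reported)
compound 2 `Cc1ccc(CN2CCC=C(CCC(=O)NO)C2=O)cc1` - 1430 nM

For the measured compounds named here, in a functional assay on MDA-MB-231 cells (Homo sapiens) for inhibition, read by sulforhodamine B assay (a higher number here means a weaker inhibitor of growth, a lower number a stronger inhibitor of growth), compound 2 carries the only number available (1430 nM). On these data alone, compound 1 has no result to set beside it ("not determined" (no result reported)), so compound 2 can be ranked against nothing, and whether its value is good or poor for this series remains open.

The next compound to be tested is compound 3 `Cc1ccccc1CN1CCC=C(CCC(=O)NO)C1=O`. It keeps the core of compound 2 and changes only the aromatic group: 2-methylphenyl in place of 4-methylphenyl on a saturated chain carbon bound to an amide-type nitrogen in a ring. The methyl group stays on the ring, and the change amounts to 2-methylphenyl taking the place of 4-methylphenyl.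

Going by the values given here, no measured step between related compounds exists to show how much such a change matters in this assay. Among the compounds with values here, the only anchor is compound 2 at 1430 nM, so no direction can be argued and no step beyond the usual scatter is expected. The estimated change is a 1.0-fold higher number from compound 2 to compound 3 (0.02 log units; within the scatter), and this is an expectation only. Compound 3 is expected at 1500 nM, with an estimated range from 600 nM to 3500 nM.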

Compound 3, concentration for 50% growth inhibition: 4920 nM
Beside the measured number, compound 3's estimate is 3.3-fold (0.52 log units) below it; the whole stated range lies below it.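

In this assay, for the compounds shown here, 2-methylphenyl in place of 4-methylphenyl on a saturated chain carbon bound to an amide-type nitrogen in a ring gives a 3.4-fold higher number from compound 2 to compound 3 (0.54 log units; beyond the scatter), the first reading of how this position responds to a change, and the step lies beyond the usual scatter. The two groups match in everything counted, with the same carbon atoms, the same aromatic ring, no hydrogen-bond donors or acceptors and no net charge, so this growth-inhibition read-out tells apart two arrangements of the same atoms, and of this pair compound 2 is the stronger inhibitor of growth. Nothing at hand gives a measured reason for the step, so its cause stays unassigned.

On these data alone, with only these two values, it remains open whether the methyl group contributes at all, since a plain phenyl group would be needed to set a baseline for both compounds. Also open, as far as these compounds go, is whether the step carries over to other groups on the aromatic ring, such as a methoxy group or a chlorine atom, or holds with a longer chain between that ring and the ring nitrogen.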